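The compounds below may be only part of what the source reports. "The series", "measured", "known", "first", "only" and "open" are said of these compounds alone.

Compound 1 `CS(=O)(=O)Nc1ccc2oc(-c3ccccc3)nc2c1`: > 63000 nM
Compound 2 `O=S(=O)(Nc1ccc(-c2nc3ccccc3o2)cc1)c1ccc(Cl)cc1`: > 63000 nM

In an assay on isolated protein for inhibition of malate dehydrogenase, mitochondrial (Sus scrofa), with stated times of 45 min and 30 min (a lower number here means a stronger inhibitor, a higher number a weaker inhibitor), compound 1 gives only a limit, > 63000 nM, not a measured number. Compound 2 likewise gives only a limit in this assay, > 63000 nM. Nothing separates the two, since both share (the limit of > 63000 nM in this assay, at which 2 of the 2 values shown sit). Compound 3, `COc1ccc(Cl)cc1S(=O)(=O)Nc1ccc2oc(-c3ccccc3)nc2c1`, has not yet been measured in this assay; it differs from compound 1 by 5-chloro-2-methoxyphenyl in place of methyl on a sulfonyl sulfur. Within the data shown here, no step between measured compounds is available to say how such a change acts here, so the expectation rests on the starting point alone. The step expected an at least 1.5-fold lower number from compound 1 to compound 3 (0.19 log units; that floor lies within the scatter) is small, most likely none beyond the scatter, though a move toward stronger inhibition cannot be ruled out. Compound 3 is therefore estimated at 40000 nM, within a range from 6000 nM to 150000 nM, with a substantial chance that this assay again reports only a limit.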

Compound 3, half-maximal inhibitory concentration: > 63000 nM
Compound 3: only a limit was reported; the forecaster's own chance of this, stated with the estimate: 55%; middle value at least 1.5-fold (0.19 log units) away from the limit.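

Among these compounds, compound 3 gives only a limit (> 63000 nM) in this assay and, like compound 1, gives no number, so no step between compound 1 and compound 3 can be read. The compounds shown leave open how strong any of them truly is, and whether any change would give a measured number: the limit of > 63000 nM in this assay, at which 3 of the 3 values shown sit.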